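Lactam for Phenyl at the Sulfonamide Aryl Group

A few compounds are considered here, and "the series" means these few. Any claim that something is new, unique, unknown or untested is made for them only; others in the source may bear on it.

Three compounds have been measured in a functional assay for agonist activity at growth hormone secretagogue receptor type 1 (Homo sapiens), read by FLIPR; on this read-out higher numbers stand for an effect only at larger amounts of compound and lower numbers for an effect already at smaller amounts:
compound 1 `C[C@@H]1CN(c2cccc(NS(=O)(=O)c3ccc(-c4ccccn4)s3)c2)C[C@H](C)N1` gives 39.8 nM
compound 2 `C[C@@H]1CN(c2ccc(F)c(NS(=O)(=O)c3ccc(-c4ccccn4)s3)c2)C[C@H](C)N1` gives 100 nM
compound 3 `COc1ccc(N2C[C@@H](C)N[C@@H](C)C2)cc1NS(=O)(=O)c1ccc(-c2ccccc2)cc1` gives 6.31 nM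

Compound 3 holds the lowest number of the three. Among the measured compounds shown here, the only one-place step measured, a 2.5-fold higher number from compound 1 to compound 2 (0.40 log units; beyond the scatter), concerns a fluoro on the central ring and does not bear on the change now made. Compound 4 `COc1ccc(N2C[C@@H](C)N[C@@H](C)C2)cc1NS(=O)(=O)c1ccc(N2CCCC2=O)cc1` differs from compound 3 by 2-oxopyrrolidin-1-yl in place of phenyl on an aromatic carbon. For the measured compounds named here, with no measured step to lean on, the size of this change is open; the estimate for compound 4 is a somewhat higher number, a 2.5-fold higher number from compound 3 to compound 4 (0.40 log units; beyond the scatter), with a wide range. In this assay compound 4 is expected to give 16 nM, between 4 nM and 63 nM.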

Compound 4, half-maximal effective concentration: 39.8 nM
Beside the measured number, compound 4's estimate is 2.5-fold (0.40 log units) below it; low and high end bracket the measured number.
By their numbers in this assay, from the lowest: compound 3; then compounds 1 and 4 (each within the scatter of the next); then compound 2.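

At this aromatic carbon, para to a large group, a non-aromatic lactam can replace the phenyl and compound 4 still gives a clear effect, yet in this assay the change brings a 6.3-fold higher number from compound 3 to compound 4 (0.80 log units; beyond the scatter) and so costs a modest amount of potency. Among the compounds shown here, this is the first measured read on this position, since the earlier step concerned only a fluoro on the central ring. Nothing at hand accounts for the size of this step.

As far as these compounds go, it remains open whether an open-chain acetamide, a morpholine or a pyridine ring at this carbon would stay closer to compound 3. From the compounds shown here alone, it is also open whether the same exchange would cost as much on the core of compound 1.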